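Amide chain extension in a methoxyphenylalkyl amide series

This account rests on a few compounds, and the source may have more. Where it says the series, first, only, none or still open, it means among the compounds named here.

Compound 1 `CCC(=O)NCCCc1ccc(OC)cc1` is the starting point; in an assay for binding affinity to melatonin receptor (Gallus gallus) (on this read-out higher numbers stand for weaker inhibition and lower numbers for stronger inhibition), compound 1 gives 2900 nM. Compound 2 `CCCC(=O)NCCCc1ccc(OC)cc1` carries methyl in place of hydrogen on a saturated chain carbon, two bonds along the chain from a carbonyl carbon; in this assay compound 2 gives 860 nM, which makes a 3.4-fold lower number from compound 1 to compound 2 (0.53 log units; beyond the scatter). Compound 3 `CCCC(=O)NCCCCc1cccc(OC)c1` rests on another core; how the core of compound 3 differs from the core of compound 1 is not broken down here. In this assay compound 3 gives 208 nM, the lowest number of the three, with compound 2 and compound 1 beyond the scatter above it.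

Compound 4 `CCCCC(=O)NCCCCc1cccc(OC)c1` has not been measured. It differs from compound 3 by methyl in place of hydrogen on a saturated chain carbon, three bonds along the chain from a carbonyl carbon. This is the same kind of change as that from compound 1 to compound 2, not the same change: there the methyl enters two bonds along the chain from a carbonyl carbon, here three bonds along the chain from a carbonyl carbon, and the cores differ. Among the compounds with values here, the step expected here is a 1.4-fold lower number from compound 3 to compound 4 (0.14 log units; within the scatter), smaller than the earlier one because a 3.4-fold lower number from compound 1 to compound 2 (0.53 log units; beyond the scatter) is the only precedent and it sits at a different place and on a different core. Compound 4 is therefore estimated at 150 nM in this assay, expected between 50 nM and 500 nM.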

Compound 4, inhibition constant: 9670 nM
For compound 4 the middle estimate is 64-fold (1.81 log units) below the measured one, and the stated range ends below it.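

On the core of compound 3, methyl in place of hydrogen on a saturated chain carbon, three bonds along the chain from a carbonyl carbon, gives in this assay a 46-fold higher number from compound 3 to compound 4 (1.67 log units; beyond the scatter), a large loss set against the gain seen earlier on the core of compound 1. Across these two cores, this kind of chain extension does not carry over in size or in direction: the same change on two cores in this assay, a 3.4-fold lower number (0.53 log units; beyond the scatter) from compound 1 to compound 2 and a 46-fold higher number (1.67 log units; beyond the scatter) from compound 3 to compound 4, 160-fold (2.20 log units) apart, beyond the scatter of two such steps. The comparison does not show that the core alone sets the outcome, since the two steps also differ in place, two bonds along the chain from a carbonyl carbon in one and three bonds in the other, and each core supplies a single step.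

Open, as far as these compounds go, is how the ethyl to propyl step behaves on the core of compound 3 and the propyl to butyl step on the core of compound 1, which would separate core from place. Also open, from the compounds shown here alone, is how a pentyl chain or a branched isopropyl group would read on either core.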